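A few compounds are considered here, and "the series" means these few. Any claim that something is new, unique, unknown or untested is made for them only; others in the source may bear on it.

Working notes on the series. Compound 1 `Cc1nc(SCC(=O)Nc2nc(-c3ccc(Cl)cc3)cs2)n(Nc2ccccc2)c1C` is the anchor. In a functional assay on MDA-MB-231 cells (Homo sapiens) for antiproliferative activity, read by sulforhodamine B assay, with a stated time of 48 h (a lower number here means a stronger inhibitor of growth, a higher number a weaker inhibitor of growth), compound 1 gives 15200 nM. Within the data shown here, that is the only number in the set so far; the other entry is the limit of > 100000 nM in this assay, at which 1 of the 2 values shown sits. Among the measured compounds shown here, compound 2 `Cc1ccc(Nn2c(SCC(=O)Nc3nc(-c4ccccc4)cs3)nc(C)c2C)cc1` differs from compound 1 in more than one place, so the pair yields no single readable step. In this assay compound 2 gives > 100000 nM, which is a limit of the assay and not a number.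

Compound 3 `COc1ccc(Nn2c(SCC(=O)Nc3nc(-c4ccc(Cl)cc4)cs3)nc(C)c2C)cc1` is the next target. Against compound 1 the change is methoxy in place of hydrogen on an aromatic carbon: a methoxy in place of hydrogen on an aromatic carbon of the anilino ring, para to a large group. For the measured compounds named here, no measured step covers this change, so the expectation rests on compound 1 alone and on the fact that compound 2, the only other measured member, sits at the assay limit. The step is expected to go toward weaker inhibition, of a size likely to exceed the usual scatter, as a 2.3-fold higher number from compound 1 to compound 3 (0.36 log units; beyond the scatter). Compound 3 is estimated at 35000 nM, with a range from 10000 nM to 100000 nM, and a real chance that only a limit is returned.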

Compound 3, concentration for total growth inhibition: > 100000 nM
Compound 3 was reported as a limit (the forecaster's own chance of this, stated with the estimate: 30%); middle value at least 2.8-fold (0.45 log units) from the limit.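

Among these compounds, on the anilino ring of compound 1, methoxy in place of hydrogen on an aromatic carbon, para to a large group, gives the first single change that can be read, and in this assay it is an at least 6.5-fold higher number from compound 1 to compound 3 (0.81 log units; beyond the scatter). The result for compound 3 is a limit of the assay and not a number, so the step fixes a direction and a minimum size but no end point, and this position is now shown to be one where a single added group can move growth inhibition beyond the scatter. Compound 1 is the only member that still carries a number, while compound 3 joins compound 2 at the top of the read-out: the limit of > 100000 nM in this assay, at which 2 of the 3 values shown sit.

On these data alone, what remains open is whether the loss belongs to methoxy in particular or to any group at this place, which a fluorine, a hydroxyl or an amine on the same ring carbon would help to separate. Among the compounds shown here, no other step in the set can be read, so the contribution of the remaining parts of the core of compound 1 is still unknown.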